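A few compounds are considered here, and "the series" means these few. Any claim that something is new, unique, unknown or untested is made for them only; others in the source may bear on it.

Compound 1 `CNc1c(C#N)c2c(N)ncnc2n1COCCOC` is a weak inhibitor in a functional assay on KB cells (Homo sapiens) for inhibition; a higher number here means a weaker inhibitor, a lower number a stronger inhibitor. For compound 1 the reading is only a limit, > 100000 nM, which is the limit of > 100000 nM in this assay, at which 1 of the 3 values shown sits. Compound 2 `NC(=S)c1c(N)n(COCc2ccccc2)c2ncnc(N)c12` gives 225000 nM in this assay. For compound 3 `COCCOCN1c2ncnc(N)c2C(C(=N)S)C1N` the reading is again a limit, > 320000 nM, which is the limit of > 320000 nM in this assay, at which 1 of the 3 values shown sits. Compound 1 thus stands at a limit, one of the other two values is a limit too, and no order among the three can be drawn. Compound 4 `COCCOCn1c(N)c(C#N)c2c(N)ncnc21` differs from compound 1 by one change: hydrogen in place of methyl on a nitrogen on an aromatic ring. Going by the values given here, no measured pair shows this change, so the expected step that the limit leaves unreadable from compound 1 to compound 4 is none beyond the scatter. Compound 4 is expected to give 200000 nM, between 50000 nM and 800000 nM, most likely again as a limit.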

Compound 4, half-maximal inhibitory concentration: 210000 nM
The estimate for compound 4 lay 1.1-fold (0.02 log units) below the measured number, and the stated range covers the measured number.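

Going by these compounds alone, the change from methylamino to amino gives no step of readable size between compound 1 and compound 4, because compound 1 reads only as a limit: the limit of > 100000 nM in this assay, at which 1 of the 4 values shown sits.

How far methylamino and amino truly lie apart in this assay stays open among the compounds shown.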